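This account rests on a few compounds, and the source may have more. Where it says the series, first, only, none or still open, it means among the compounds named here.

Compound 1 `C=CCSc1nnc(-c2cc(OC)c(OC)c(OC)c2)n1N1C(=O)c2ccccc2C1=O` gives > 200000 nM in a functional assay on MKN-45 cells (Homo sapiens) for cytotoxicity, read by MTT assay, with a stated time of 48 h; a lower number here means a stronger inhibitor, a higher number a weaker inhibitor; this is a limit, not a number.
Compound 2 `COc1cc(-c2nnc(SCC(=O)c3ccc(Cl)cc3)n2N2C(=O)c3ccccc3C2=O)cc(OC)c1OC` gives 26600 nM.
Compound 3 `COc1cc(-c2nnc(SCC(=O)c3ccccc3)n2N2C(=O)c3ccccc3C2=O)cc(OC)c1OC` gives > 200000 nM; this too is a limit, not a number.

Compound 3 thus stands at the limit of > 200000 nM in this assay, at which 2 of the 3 values shown sit, with no number to rank it. The step from compound 2 to compound 3 is an at least 7.5-fold higher number from compound 2 to compound 3 (0.87 log units; beyond the scatter), so taking off the chloro cost at least modest potency; the step of an at least 7.5-fold lower number from compound 1 to compound 2 (0.87 log units; beyond the scatter) points the same way. Compound 4 `COc1cc(-c2nnc(SCC(=O)c3ccc(Br)cc3)n2N2C(=O)c3ccccc3C2=O)cc(OC)c1OC` differs from compound 3 by bromo in place of hydrogen on an aromatic carbon. One halogen now replaces the hydrogen where the other halogen sat in compound 2, so a return toward the level of compound 2 is expected. Compound 4 is therefore estimated at 25000 nM, in the range 8000 nM to 200000 nM. That estimate means an expected step of an at least 8.0-fold lower number from compound 3 to compound 4 (0.90 log units; beyond the scatter), though a reading at the limit remains possible.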

Compound 4, half-maximal inhibitory concentration: 22300 nM
The estimate for compound 4 lay 1.1-fold (0.05 log units) above the measured number; measured number inside the range.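

With bromo in place of hydrogen on this aromatic carbon, para to a large group, the series shows an at least 8.9-fold lower number from compound 3 to compound 4 (0.95 log units; beyond the scatter), so the gain is not confined to chloro. The two halogens cannot be told apart here, with a 1.2-fold lower number from compound 2 to compound 4 (0.08 log units; within the scatter). The (4-bromophenyl)carbonyl group also stands clear of the vinyl end of compound 1, with an at least 8.9-fold lower number from compound 1 to compound 4 (0.95 log units; beyond the scatter).

Going by these compounds, whether an amine or a carboxylic acid at this position would hold that level remains open. The full size of the gain from hydrogen also stays open because compound 3 gives only a limit: the limit of > 200000 nM in this assay, at which 2 of the 4 values shown sit.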